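The source may hold more compounds than are shown below. What is called first, only, known or untested is meant among the compounds shown, and "the series" means these compounds.

Of the compounds shown here, three sharing one core have been measured in a functional assay on SGC-7901 cells (Homo sapiens) for antiproliferative activity, read by MTT assay, with a stated time of 24 h; a higher number here means a weaker inhibitor, a lower number a stronger inhibitor. Here compound 1 (`O=C(NNc1cccc(Cl)c1)c1ccccc1NS(=O)(=O)c1cnc(O)nc1O`) gives 10800 nM, and compound 3 (`Cc1ccccc1C(=O)NNC(=O)c1ccccc1NS(=O)(=O)c1cnc(O)nc1O`) gives 13000 nM. The measured difference is a 1.2-fold higher number from compound 1 to compound 3 (0.08 log units; within the scatter), so these two numbers cannot be told apart. Compound 2 (`O=C(NNc1ccccc1F)c1ccccc1NS(=O)(=O)c1cnc(O)nc1O`) reports only a limit, > 20000 nM, and not a number.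

Compound 4 (`O=C(NNC(=O)c1ccccc1NS(=O)(=O)c1cnc(O)nc1O)c1ccccc1F`) differs from compound 3 in one place: fluoro in place of methyl on an aromatic carbon. This puts fluoro in place of methyl on an aromatic carbon, ortho to a large group. For the measured compounds named here, no measured pair makes exactly this swap. The closest evidence is compound 2, which also carries a 2-fluorophenyl group, although without the carbonyl of the (2-fluorophenyl)carbonyl group in compound 4. Its two steps are an at least 1.5-fold lower number from compound 2 to compound 3 (0.18 log units; that floor lies within the scatter) and an at least 1.8-fold higher number from compound 1 to compound 2 (0.26 log units; that floor lies within the scatter), and both are only floors set by its limit. Given those floors for compound 2, an at least 1.5-fold lower number from compound 2 to compound 3 (0.18 log units; that floor lies within the scatter) among them, a slightly higher number is expected in this assay, but no step clearly beyond the scatter. A limit rather than a number is also a real possibility.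

The estimated change is a 1.2-fold higher number from compound 3 to compound 4 (0.06 log units; within the scatter). For compound 4 the expected value is 15000 nM, with an estimated range of 8000 nM to 28000 nM.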

Compound 4, half-maximal inhibitory concentration: > 20000 nM
Compound 4 ended at the assay's limit; the forecaster's own chance of this, stated with the estimate: 35%; middle value at least 1.3-fold (0.12 log units) away from the limit.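

Fluoro in place of methyl, on an aromatic carbon ortho to a large group, can now be read directly for the first time, and in this assay it gives an at least 1.5-fold higher number from compound 3 to compound 4 (0.18 log units; that floor lies within the scatter). This figure is only a floor, so the true step may be larger, but what is printed does not place it beyond the scatter, and the same holds for the comparison with the 3-chlorophenyl compound, which gives an at least 1.8-fold higher number from compound 1 to compound 4 (0.26 log units; that floor lies within the scatter). What is new is that the (2-fluorophenyl)carbonyl group, like the 2-fluorophenyl group of compound 2, gives no readable number, so the step between compound 2 and compound 4 cannot be read, and both compounds stop at the same ceiling: the limit of > 20000 nM in this assay, at which 2 of the 4 values shown sit.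

Without a number for compound 4, the data cannot say how far the fluoro change really moves the activity, or whether that move exceeds the scatter. From the compounds shown here alone, it also remains open whether chloro, methoxy or an amine on this same aromatic carbon would give a readable number close to that of compound 3 or would also end at the limit.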